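Swapping the chain amine: from compound 3 to compound 4

A few compounds are considered here, and "the series" means these few. Any claim that something is new, unique, unknown or untested is made for them only; others in the source may bear on it.

Of the compounds shown here, three sharing one core have been tested in a functional assay on A549 cells (Homo sapiens) for cytotoxicity, read by MTT assay, with a stated time of 72 h; a higher number here means a weaker inhibitor, a lower number a stronger inhibitor. Compound 1 `COc1cc2c(Oc3ccc(NC(=O)c4nnn(-c5ccccc5C(F)(F)F)c4C)cc3F)ccnc2cc1OCCCN1CCCCC1` gives 170 nM. Compound 2 `COc1cc2c(Oc3ccc(NC(=O)c4nnn(-c5ccc(F)cc5)c4C(F)(F)F)cc3F)ccnc2cc1OCCCN1CCCCC1` gives 110 nM. Compound 3 `COc1cc2c(Oc3ccc(NC(=O)c4nnn(-c5ccc(F)c(F)c5)c4C(F)(F)F)cc3F)ccnc2cc1OCCCN1CCCCC1` gives 160 nM. Among the compounds with values here, the only single-point step among the three, a 1.5-fold higher number from compound 2 to compound 3 (0.16 log units; within the scatter), concerns fluoro in place of hydrogen on an aromatic carbon. The number for compound 3 lies within the scatter of both the number for compound 1 and the number for compound 2, so none of the three can be called stronger or weaker than another.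

Compound 4 `COc1cc2c(Oc3ccc(NC(=O)c4nnn(-c5ccc(F)c(F)c5)c4C(F)(F)F)cc3F)ccnc2cc1OCCCN1CCN(C)CC1` is the compound yet to be measured. It differs from compound 3 in one place: 4-methylpiperazin-1-yl in place of piperidin-1-yl on a saturated chain carbon, three bonds along the chain from an oxygen on an aromatic ring. Within the data shown here, no measured step touches this part of the molecule; the single step on record changes a substituent on an aromatic ring, not the chain amine, and that step stayed within the scatter. There is thus nothing in these data that points to a move in either direction. The expected outcome in this assay is no change at the digits printed from compound 3 to compound 4 (within the scatter), in other words no change beyond the scatter. The estimate for compound 4 is 160 nM, with a range from 70 nM to 370 nM.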

Compound 4, half-maximal inhibitory concentration: 130 nM
The estimate for compound 4 lay 1.2-fold (0.09 log units) above the measured number; the range from low to high includes it.
By their numbers in this assay, from the lowest: compounds 2, 4, 3 and 1 (each within the scatter of the next).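

Within the data shown here, this is the first measured change at the chain amine, the part of the molecule farthest along the chain from the aromatic oxygen. In this assay, replacing piperidin-1-yl with 4-methylpiperazin-1-yl gives a 1.2-fold lower number from compound 3 to compound 4 (0.09 log units; within the scatter) and so adds a second ring nitrogen and its methyl group with no readable effect on the result. For this one pair, the 3-(piperidin-1-yl)propyl group can therefore be exchanged for the 3-(4-methylpiperazin-1-yl)propyl group while the number stays within the usual scatter, and no measurement shown here explains why.

On these data alone, whether the same holds for a very different chain amine, such as morpholin-4-yl, dimethylamino or a primary amine, remains open, as does the effect of a carboxylic acid at the chain end or of shortening the chain to 2-(4-methylpiperazin-1-yl)ethyl. It is also open whether this swap would give a similar outcome with the other triazole-free variations of the side opposite the chain, since only a single pair carrying the change is shown.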